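The compounds below may be only part of what the source reports. "The series", "measured", "known", "first", "only" and "open" are said of these compounds alone.

Compound 1 `C[C@H](Nc1c(C(N)=O)nnc2ccc(-c3ccc(OCCCN4CCCC4)nc3)cc12)C1CCOCC1` and compound 2 `Cc1cn(C)nc1[C@H](C)Nc1c(C(N)=O)nnc2ccc(-c3ccc(OCCCN4CCCC4)nc3)cc12` share one core and differ in a single place: 1,4-dimethyl-1H-pyrazol-3-yl in place of oxan-4-yl on a saturated chain carbon bound to a nitrogen on an aromatic ring and a saturated chain carbon. In an assay on HT-29 cells for inhibition of Serine-protein kinase ATM (Homo sapiens), read by fluorescence, with a stated time of 1 h (on this read-out higher numbers stand for weaker inhibition and lower numbers for stronger inhibition), compound 1 gives 1.8 nM, and compound 2 gives 0.5 nM; the step is a 3.6-fold lower number from compound 1 to compound 2 (0.56 log units; beyond the scatter). Compound 3 `CNC(=O)c1nnc2ccc(-c3ccc(OCCCN(C)C)nc3)cc2c1N[C@@H](C)C1CCOCC1` rests on a core that is not the core of compound 1; the difference between the two cores is not broken down here. In this assay compound 3 gives 2.8 nM. Compound 4 `CNC(=O)c1nnc2ccc(-c3ccc(OCCCN(C)C)nc3)cc2c1N[C@@H](C)c1nn(C)cc1C` arises from compound 3 by the same change as before, (1,4-dimethyl-1H-pyrazol-3-yl in place of oxan-4-yl on a saturated chain carbon bound to a nitrogen on an aromatic ring and a saturated chain carbon), made at the same place. Compound 4 has not yet been measured in this assay. The step from compound 3 to compound 4 is expected to be a 3.1-fold lower number from compound 3 to compound 4 (0.49 log units; beyond the scatter). For the measured compounds named here, that expectation rests on the only measured instance of this change, which is a 3.6-fold lower number from compound 1 to compound 2 (0.56 log units; beyond the scatter). Compound 4 is accordingly estimated at 0.9 nM, with a likely range from 0.4 nM to 2 nM.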

Compound 4, half-maximal inhibitory concentration in the Serine-protein kinase ATM assay: 3.9 nM
The estimate for compound 4 lay 4.3-fold (0.64 log units) below the measured number; measured number above the stated range.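

In the Serine-protein kinase ATM assay compound 3 gives 2.8 nM and compound 4 gives 3.9 nM. In the Serine-protein kinase ATM assay the change gives a 1.4-fold higher number from compound 3 to compound 4 (0.14 log units; within the scatter), so the clear gain seen on the core of compound 1 does not reappear on the core of compound 3, and the two results differ: the same change on two cores in the Serine-protein kinase ATM assay, a 3.6-fold lower number (0.56 log units; beyond the scatter) from compound 1 to compound 2 and a 1.4-fold higher number (0.14 log units; within the scatter) from compound 3 to compound 4, 5.0-fold (0.70 log units) apart, beyond the scatter of two such steps

In a physicochemical assay for lipophilicity, using the shake flask method, measured as octanol-water partition, with a stated time of 30 min, at pH 7.4 (a lower number here means a more polar compound, a higher number a more lipophilic compound), compound 3 gives 2.3 and compound 4 gives 2.3.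

This shows that, in these two pairs, the effect of putting 1,4-dimethyl-1H-pyrazol-3-yl in place of oxan-4-yl depends on the core that carries it, so a single measured instance was a poor guide. It does not show which part of the difference between the two cores is responsible, and two pairs give no rule for other cores.

The compounds shown leave open how a phenyl group in place of oxan-4-yl would fare on these two cores. They also leave open which way the step would go on a third core.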